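The source may hold more compounds than are shown below. What is called first, only, known or untested is meant among the compounds shown, and "the series" means these compounds.

Measured so far, in a functional assay on isolated protein for agonist activity at Glucose-dependent insulinotropic receptor (Rattus norvegicus), read by HTRF and cAMP accumulation; a lower number here means that less compound is needed, a higher number that more compound is needed for the effect:

Compound 1, `CC(C)(C)OC(=O)N1CCC(O[C@H]2CC[C@H](Oc3ccc(S(C)(=O)=O)cc3)CC2)CC1`: 94 nM
Compound 2, `CC(C)(C)OC(=O)N1CCC(O[C@H]2CC[C@H](Oc3ccc(S(C)(=O)=O)cn3)CC2)CC1`: 110 nM
Compound 3, `CS(=O)(=O)c1cnc(O[C@H]2CC[C@H](OC3CCN(C(=O)OC4CCOC4)CC3)CC2)cn1`: 1500 nM

Compound 3 stands at the highest of the three numbers in this assay. Compound 2 lies beneath it, and compound 1 lower still, and both of those gaps are beyond the scatter. For the measured compounds named here, the single step between compounds that differ in one place, a 1.2-fold higher number from compound 1 to compound 2 (0.07 log units; within the scatter), concerns the aryl group on the oxygen and is within the scatter; it does not touch the part of the molecule that changes next.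

Compound 4, `CS(=O)(=O)c1cnc(O[C@H]2CC[C@H](OC3CCN(CC4(C(F)(F)F)CCC4)CC3)CC2)cn1`, arises from compound 3 by the change ((1-(trifluoromethyl)cyclobutyl)methyl in place of ((oxolan-3-yl)oxy)carbonyl on an amine nitrogen in a ring). The ring nitrogen thus loses its carbamate and carries a plain alkyl substituent instead. Going by the values given here, no measured step bears on this kind of exchange: the one step recorded lies elsewhere, and compound 3 differs from compounds 1 and 2 in two places at once, so its distance from them cannot be assigned to the carbamate alone. The direction of the step is therefore open, and a change within the scatter is as plausible as a move in either direction. For compound 4 the number in this assay is estimated at 800 nM, with a range from 120 nM to 5000 nM, which corresponds to an expected step of a 1.9-fold lower number from compound 3 to compound 4 (0.27 log units; within the scatter).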

Compound 4, half-maximal effective concentration: 80 nM
The estimate for compound 4 lay 10-fold (1.00 log units) above the measured number; measured number below the stated range.
By their numbers in this assay, from the lowest: compounds 4, 1 and 2 (each within the scatter of the next); then compound 3.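

At the amine nitrogen in the six-membered ring, in this assay, putting (1-(trifluoromethyl)cyclobutyl)methyl in place of ((oxolan-3-yl)oxy)carbonyl gives a 19-fold lower number from compound 3 to compound 4 (1.27 log units; beyond the scatter). For the compounds shown here, this is the first measured step at this position, and it shows that the number responds strongly to what the nitrogen carries. It also shows that, within this pair, a low number does not depend on a carbonyl at this place or on the hydrogen-bond acceptors of the departing group, as the entering group has none; no measurement given here accounts for the size of the step.

Going by these compounds alone, the single exchange replaces the whole substituent, so the trifluoromethyl group, the cyclobutane ring and the loss of the carbamate cannot be told apart; a plain cyclobutylmethyl group or a neopentyl chain on the same nitrogen would separate these contributions. As far as these compounds go, it also remains open how an amide or a sulfonamide at this nitrogen would compare, and whether the same exchange would give a step of similar size on the aryl groups of compound 1 and compound 2.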